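A few compounds are considered here, and "the series" means these few. Any claim that something is new, unique, unknown or untested is made for them only; others in the source may bear on it.

Measured so far in an ADME assay on MT4 cells (Homo sapiens) for cytotoxicity; on this read-out higher numbers stand for lower toxicity in this test and lower numbers for higher toxicity in this test:
- compound 1 `COC(=O)N[C@H](C(=O)NN(CCC[C@](O)(Cc1ccccc1)C(=O)N[C@H]1c2ccccc2C[C@H]1O)Cc1ccc(Br)cc1)C(C)(C)C`: > 10000 nM
- compound 2 `COC(=O)N[C@H](C(=O)NN(CCC[C@@](O)(Cc1ccccc1)C(=O)N[C@H]1c2ccccc2C[C@H]1O)Cc1ccc(-c2ccccn2)cc1)C(C)(C)C`: > 10000 nM

The value of compound 2 in this assay is a limit of the assay, not a number. The reading of compound 1 in this assay is likewise a limit. For the measured compounds named here, both readings therefore stand at the limit of > 10000 nM in this assay, at which 2 of the 2 values shown sit, and no step between the two can be sized from them.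

Compound 3 `COC(=O)N[C@H](C(=O)NN(CCC[C@@](O)(Cc1ccccc1)C(=O)N[C@H]1c2ccccc2C[C@H]1O)Cc1ccc(I)cc1)C(C)(C)C` follows from compound 2 by a single change: iodo in place of pyridin-2-yl on an aromatic carbon. Going by the values given here, no step has yet been measured with a number on either side, so the size of this step cannot be read off from an earlier one. With compound 2 sitting at the limit, the step from compound 2 to compound 3 is expected to be a step that the limit leaves unreadable from compound 2 to compound 3, nothing beyond the usual scatter. Compound 3 is therefore expected to give about 15000 nM in this assay, within 8000 nM to 40000 nM, most likely again reported only as a limit.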

Compound 3, half-maximal cytotoxic concentration: > 10000 nM
Compound 3 was reported as a limit; the forecaster's own chance of this, stated with the estimate: 85%; the middle value lies beyond the limit too.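

No step from compound 2 to compound 3 can be read, as both readings stand at one limit of the assay and neither is a number: the limit of > 10000 nM in this assay, at which 3 of the 3 values shown sit.

The compounds shown leave open at what concentration any of them would give a number in this assay, and whether iodo and pyridin-2-yl would then differ.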